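This account rests on a few compounds, and the source may have more. Where it says the series, first, only, none or still open, it means among the compounds named here.

Compound 2 `O=C(Nc1cccc(-n2cc(-c3ccncc3)c(-c3cc(O)cc(Cl)c3)n2)c1)Nc1ccc(Cl)c(Cl)c1` and compound 1 `O=C(Nc1cccc(-n2cc(-c3ccncc3)c(-c3cc(O)cc(Cl)c3)n2)c1)Nc1ccc(Cl)c(C(F)(F)F)c1` share a core that differs only at the outer urea aryl ring. In a functional assay on MOLT-4 cells (Homo sapiens) for inhibition, read by sulforhodamine B assay, with a stated time of 48 h, tested at 10 uM (a higher number here means a weaker effect of the compound at the concentration tested, a lower number a stronger effect), compound 1 gives -18%, and compound 2 gives -27.1%, so compound 2 sits alongside compound 1 within the usual scatter, the step being a number 9.1 percentage points lower from compound 1 to compound 2 (within the scatter). Compound 3 `COc1cc(Cl)cc(-c2nn(-c3cccc(NC(=O)Nc4ccc(Cl)c(Cl)c4)c3)cc2-c2ccncc2)c1` is reached from compound 2 by methyl in place of hydrogen on an oxygen on an aromatic ring. Within the data shown here, the one measured step concerns a chloro replacing a trifluoromethyl on a different ring and says nothing about a change on the oxygen on the aromatic ring, so no measured step bears on this move. The expectation for compound 3 therefore rests on the two values alone, and a step of a number 12.1 percentage points higher from compound 2 to compound 3 (beyond the scatter) is expected in this assay, with no direction claimed beyond the scatter. Compound 3 is estimated to give -15%, between -50% and 30%, in this assay.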

Compound 3, a percentage reported as activity, at one concentration (the size of the read-out at that concentration, not a potency): -16.1%
Estimate against measurement, compound 3: 1.1 percentage points above; the measured number falls inside the stated range.
By their numbers in this assay, from the lowest: compounds 2, 1 and 3 (each within the scatter of the next, the first and the last beyond it).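

Replacing the hydrogen on the oxygen with methyl, hydroxy to methoxy, gives a modest change in this assay, a number 11 percentage points higher from compound 2 to compound 3 (beyond the scatter), and the higher number means a weaker effect at the concentration tested. Unlike the earlier step on the outer urea aryl ring, which stayed within the scatter, this shows that the read-out responds to a change at the oxygen on the 3-chloro-5-hydroxyphenyl ring, although compound 3 still gives a negative number, -16.1%. No supporting evidence is available to explain this step.

The compounds shown leave open whether an ethyl or a longer chain on the oxygen would extend this step, and how an amine or a carboxylic acid in place of hydroxy would read. They also leave open whether methoxy would give a similar step alongside the trifluoromethyl of compound 1.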